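The source may hold more compounds than are shown below. What is called first, only, known or untested is meant among the compounds shown, and "the series" means these compounds.

Measured in a physicochemical assay for solubility, read by spectrophotometry, in phosphate buffer, measured as kinetic solubility, with a stated time of 18 h, at pH 7.4; on this read-out lower numbers stand for lower solubility and higher numbers for higher solubility:
compound 1 `COc1ccc(-c2nc3ccccc3o2)cc1NC(=O)c1cc([N+](=O)[O-])ccc1Cl` gives 90 nM
compound 2 `O=C(Nc1cc(-c2nc3ccccc3s2)ccc1Cl)c1cc([N+](=O)[O-])ccc1Cl` gives 100 nM
compound 3 `O=C(Nc1cccc(-c2nc3ccccc3[nH]2)c1)c1cc([N+](=O)[O-])ccc1Cl` gives 1400 nM

Compound 1 and compound 2 lie within the scatter of each other, while compound 3 stands beyond the scatter, higher than both. Compound 1 therefore belongs to the low pair of this small set. Compound 4 `Cc1ccc(-c2nc3ccccc3o2)cc1NC(=O)c1cc([N+](=O)[O-])ccc1Cl` has methyl in place of methoxy on an aromatic carbon, ortho to a large group and para to a 1,3-benzoxazol-2-yl group. Going by the values given here, no measured pair isolates this change, so no step beyond the scatter is expected in this assay, and no direction can be argued from the data. The expectation is anchored on compound 1 at 90 nM. The estimated 1.1-fold lower number from compound 1 to compound 4 (0.02 log units; within the scatter) is small. For compound 4 the expected value is 85 nM, with an estimated range of 35 nM to 250 nM.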

Compound 4, solubility: 310 nM
Beside the measured number, compound 4's estimate is 3.6-fold (0.56 log units) below it, outside the stated range (above it).
By their numbers in this assay, from the lowest: compounds 1 and 2 (each within the scatter of the next); then compound 4; then compound 3.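

In this assay, the aromatic carbon ortho to a large group and para to a 1,3-benzoxazol-2-yl group proves sensitive to substitution. Methyl in place of methoxy there gives a 3.4-fold higher number from compound 1 to compound 4 (0.54 log units; beyond the scatter) as the first single-place step in the series, beyond the scatter but modest in size. No measurement shown accounts for this step. The compounds shown leave open how an amine, a hydroxyl or a longer chain on this carbon would read. Going by these compounds, whether the step carries over to a different core also remains open.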